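A few compounds are considered here, and "the series" means these few. Any claim that something is new, unique, unknown or untested is made for them only; others in the source may bear on it.

Working notes on the series.

Compound 1 `N=C1S/C(=C\c2ccc(OCc3ccccc3)cc2)C(=O)N1c1ccc(Cl)cc1` is the reference point. In an ADME assay on RAW264.7 cells (Mus musculus) for cytotoxicity, read by MTT assay, with a stated time of 48 h, tested at 50 uM (a lower number here means less inhibition, a higher number more inhibition at the concentration tested (going by the name of the read-out)), compound 1 gives 16.4%. Among the compounds with values here, compound 2 `N=C1S/C(=C\c2ccc(OCc3ccccc3)cc2)C(=O)N1c1ccc(Cl)cc1Cl` is its only measured neighbour; in this assay compound 2 gives 13.8%. Within the data shown here, the single measured step, a number 2.6 percentage points lower from compound 1 to compound 2 (within the scatter), concerns a chloro in place of hydrogen on an aromatic carbon and does not separate the two compounds beyond the scatter, so compound 1 cannot be ranked against compound 2 on these numbers.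

Compound 3 `Cc1ccc(C)c(N2C(=N)S/C(=C\c3ccc(OCc4ccccc4)cc3)C2=O)c1` has not yet been measured. It differs from compound 1 by 2,5-dimethylphenyl in place of 4-chlorophenyl on an amide-type nitrogen in a ring. Among the measured compounds shown here, no measured step exchanges the whole aryl group on the amide-type nitrogen in the ring, so the one step on record bears only loosely on this change; what it shows is that altering the substitution of that aryl group moved this assay little. On that basis no step beyond the scatter is expected in this assay for compound 3, in either direction. Compound 3 is estimated at 15%, with a range from 5% to 28%, which means an expected step of a number 1.4 percentage points lower from compound 1 to compound 3 (within the scatter).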

Compound 3, a percentage reported as inhibition, at one concentration (the size of the read-out at that concentration, not a potency): 45.8%
The estimate for compound 3 lay 30.8 percentage points below the measured number; the whole stated range lies below it.
By their numbers in this assay, from the lowest: compounds 2 and 1 (each within the scatter of the next); then compound 3.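

In this assay the exchange of the whole aryl group on the amide-type nitrogen in a ring gives a number 29.4 percentage points higher from compound 1 to compound 3 (beyond the scatter) and also a number 32 percentage points higher from compound 2 to compound 3 (beyond the scatter) in the same read-out, so this position can move the number beyond the scatter, which the chloro step alone did not show. Compound 1 and compound 2 stay within the scatter of each other while compound 3 stands apart from both, so among these three compounds the difference goes with 2,5-dimethylphenyl in place of either chlorinated aryl group and not with the added chloro. Nothing at hand bears on why this exchange changes the read-out.

From the compounds shown here alone, whether the higher number needs both methyl groups or follows from one of them alone, and whether it depends on the absence of chlorine from the aryl group, stays open. Going by these compounds, how a methoxy group, an amine or a carboxylic acid on that aryl group would read in this assay is open as well, so the shape of this position beyond these three compounds remains unknown.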